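Replacing 4-fluorophenyl with difluoromethyl on the shared core

The source may hold more compounds than are shown below. What is called first, only, known or untested is meant among the compounds shown, and "the series" means these compounds.

In an ADME assay on microsomes from liver (Rattus norvegicus) for metabolic stability, with a stated time of 10 min, tested at 0.5 uM (on this read-out higher numbers stand for a more stable compound and lower numbers for a less stable compound), compound 3 (`Cc1noc(-c2ccc(F)cc2)c1[C@@H]1C[C@@](C)(c2ccc(F)cc2F)N=C(N)S1`) gives 88% remaining. Compound 1 (`Cc1noc(C)c1[C@@H]1C[C@@](C)(c2ccc(F)cc2F)N=C(N)S1`) gives 78% remaining, and the two stand level, the gap being (a number 10 percentage points higher from compound 1 to compound 3 (within the scatter)). Compound 2 (`Cc1noc(-c2ccccc2)c1[C@@H]1C[C@@](C)(c2ccc(F)cc2F)N=C(N)S1`) stands far from both at 20% remaining, with (a number 58 percentage points lower from compound 1 to compound 2 (beyond the scatter)) and (a number 68 percentage points higher from compound 2 to compound 3 (beyond the scatter)) both large.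

Compound 4 (`Cc1noc(C(F)F)c1[C@@H]1C[C@@](C)(c2ccc(F)cc2F)N=C(N)S1`) has difluoromethyl in place of 4-fluorophenyl on an aromatic carbon. Going by the values given here, no measured compound carries difluoromethyl at this place. The nearest guide is compound 1, whose methyl also brings no ring there and which gives 78% remaining. Methyl and 4-fluorophenyl thus read alike, whereas the large steps around compound 2 show that this place can matter, so the range is left wide on the low side. No step beyond the scatter is expected, and the estimated change is (a number 10 percentage points lower from compound 3 to compound 4 (within the scatter)). The estimate for compound 4 is 78% remaining, with an expected range of 55% to 92% remaining.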

Compound 4, percent of the compound remaining: 67%
For compound 4 the middle estimate is 11 percentage points above the measured one; low and high end bracket the measured number.
By their numbers in this assay, from the lowest: compound 2; then compound 4; then compounds 1 and 3 (each within the scatter of the next).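

Going by these compounds alone, at the place next to the ring oxygen, difluoromethyl is the first group to separate from both methyl and 4-fluorophenyl, which had read level: the modest drops are (a number 11 percentage points lower from compound 1 to compound 4 (beyond the scatter)) and (a number 21 percentage points lower from compound 3 to compound 4 (beyond the scatter)). It nevertheless stays far from the low level of the unsubstituted phenyl (a number 47 percentage points higher from compound 2 to compound 4 (beyond the scatter)), so this place now gives three levels of stability rather than two, and the ring-bearing compounds 2 and 3 stand at opposite ends with the ringless compounds 1 and 4 not sharing a single level. Nothing at hand accounts for these differences.

From the compounds shown here alone, whether trifluoromethyl or fluoromethyl at this place would stand with compound 4 or with compound 1 remains open. So does whether chloro or methoxy in place of the fluoro of compound 3 would hold its level or fall towards that of compound 2.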